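From methyl to methoxycarbonyl on the shared core

The source may hold more compounds than are shown below. What is called first, only, known or untested is meant among the compounds shown, and "the series" means these compounds.

Of the compounds shown here, three with a shared core have been measured in a functional assay on the whole organism with Rattus norvegicus as the target; a higher number here means that more compound is needed for the effect, a lower number that less compound is needed. Compound 1 `CCOC(=O)C(=O)Nc1cccc(N)c1C#N` gives 0.05 mg/kg, compound 2 `CCOC(=O)C(=O)Nc1cccc(N(C)C(C)C)c1C#N` gives 0.3 mg/kg, and compound 3 `CCOC(=O)C(=O)Nc1cccc(C)c1C#N` gives 5.3 mg/kg, the highest number of the three. The next change leads to compound 4 `CCOC(=O)C(=O)Nc1cccc(C(=O)OC)c1C#N`, with methoxycarbonyl in place of methyl on an aromatic carbon.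

Two measured steps end at the methyl group of compound 3, and both are large: a 110-fold higher number from compound 1 to compound 3 (2.03 log units; beyond the scatter) and an 18-fold higher number from compound 2 to compound 3 (1.25 log units; beyond the scatter). The step between the two amino compounds is smaller, at a 6.0-fold higher number from compound 1 to compound 2 (0.78 log units; beyond the scatter). So the number in this assay moves strongly with the group at this place, and among these three compounds methyl carries the highest number. Going by the values given here, neither comparison group is an ester, however, and no measured compound carries methoxycarbonyl here, so these steps give only a loose guide. A lower number than that of compound 3 is expected, though by less than either large step. The expected step is a 3.5-fold lower number from compound 3 to compound 4 (0.55 log units; beyond the scatter), a modest fall with real uncertainty. For compound 4 the estimated value is 1.5 mg/kg, with an expected range from 0.2 mg/kg to 10 mg/kg.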

Compound 4, dose for half-maximal effect: 1.2 mg/kg
Compound 4: the middle estimate sits 1.3-fold (0.10 log units) above what was measured; measured number inside the range.
By their numbers in this assay, from the lowest: compound 1; then compound 2; then compound 4; then compound 3.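

Replacing methyl with methoxycarbonyl gives a 4.4-fold lower number from compound 3 to compound 4 (0.65 log units; beyond the scatter) in this assay and shows that this place tolerates a group other than an amine without the number rising to that of compound 3. Yet the ester does not reach either amino compound: there is a 4.0-fold higher number from compound 2 to compound 4 (0.60 log units; beyond the scatter) and a still wider gap of a 24-fold higher number from compound 1 to compound 4 (1.38 log units; beyond the scatter) in the same assay, so both nitrogen-linked groups keep lower numbers than methoxycarbonyl, and methyl stays highest of the four. The four groups now spread in a single order, amino, isopropyl(methyl)amino, methoxycarbonyl and methyl, and no information is available on why the ester falls where it does.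

The compounds shown leave open whether a carboxylic acid, a primary carboxamide or a longer ester such as ethoxycarbonyl at this place would stay near methoxycarbonyl or move towards the amino compounds. They also leave open whether a methoxy or hydroxyl group, attached through oxygen rather than through nitrogen or carbon, would give a number as low as that of compound 1 or one closer to that of compound 3.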